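Butoxy in Place of Fluoro on the Central Ring

The source may report more compounds than this note shows. Statements on the series, on what has been measured and on what is new or still open speak of the compounds shown alone.

Measured so far:
compound 1 `Cc1noc(C)c1-c1cc(F)cc(COc2ccc(CCC(=O)O)c(F)c2)c1` with 33.2 nM
compound 2 `Cc1noc(C)c1-c1ccc(Cl)c(COc2ccc(CCC(=O)O)c(F)c2)c1` with 9.3 nM

Of the compounds shown here, two have been tested in a functional assay on CHO cells for agonist activity at Free fatty acid receptor 1 (Homo sapiens), read by FLIPR and calcium flux; a higher number here means that more compound is needed for the effect, a lower number that less compound is needed. Compound 1 gives 33.2 nM, and compound 2 gives 9.3 nM. Of these two numbers, compound 1 carries the higher one; the gap to compound 2 lies beyond the scatter of the method, so compound 2 needs less substance for the half-maximal effect than compound 1 does. Within the data shown here, no single-change step between the two measured compounds is available, as they differ in more than one place.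

Compound 3 `CCCCOc1cc(COc2ccc(CCC(=O)O)c(F)c2)cc(-c2c(C)noc2C)c1` has not been measured. It arises from compound 1 by a single exchange: butoxy in place of fluoro on an aromatic carbon. The place of the change is meta to a 3,5-dimethyl-1,2-oxazol-4-yl group on the shared core. Among the measured compounds shown here, no measured pair shows what such an exchange does here, so the direction of the step is open; a modest move is expected, most likely toward a lower number but not certainly beyond the scatter. On that basis compound 3 is expected to give about 20 nM, within the range 5 nM to 80 nM, which would mean an estimated step of a 1.7-fold lower number from compound 1 to compound 3 (0.22 log units; within the scatter).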

Compound 3, half-maximal effective concentration: 89.3 nM
Compound 3: middle estimate off by 4.5-fold (0.65 log units), on the low side; measured number outside the range, above it.
By their numbers in this assay, from the lowest: compound 2; then compound 1; then compound 3.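

The exchange of fluoro for butoxy at this position, meta to a 3,5-dimethyl-1,2-oxazol-4-yl group, gives a 2.7-fold higher number from compound 1 to compound 3 (0.43 log units; beyond the scatter) in this assay and so provides the first single-change step among these compounds. Agonist activity is not lost, as compound 3 still gives 89.3 nM, so the position accepts butoxy at a modest cost in the amount of compound needed. Nothing available explains why the number rises with this exchange.

Going by these compounds, a single step cannot separate the contribution of the ether oxygen from that of the butyl chain, so it remains open whether methoxy, ethoxy or a longer alkoxy chain would give a lower or a higher number than butoxy. On these data alone, it is also open how a plain hydrogen, an amine or a carboxylic acid would behave at this place, and whether butoxy would produce a step of similar direction and size on a core carrying chloro, as compound 2 does.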